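Trimming the piperazine of compound 2

This account rests on a few compounds, and the source may have more. Where it says the series, first, only, none or still open, it means among the compounds named here.

Measured in an ADME assay on the whole organism (Rattus norvegicus, strain Sprague-Dawley) for pharmacokinetics, with a stated time of 6 h, at a dose of 10 mg/kg by the oral route; a lower number here means less compound in the circulation, a higher number more compound in the circulation at the dose given:
Compound 1 `Cc1cn2cc(-c3cc4ccc(N5CCN(C)CC5)cc4oc3=O)nc2cn1`: < 10 ng.h/mL, a limit and not a number
Compound 2 `CCN1CCN(c2ccc3cc(-c4cn5cc(C)nc(C)c5n4)c(=O)oc3c2)C[C@@H]1C`: 1100 ng.h/mL

For the measured compounds named here, compound 2 holds the only actual number so far, 1100 ng.h/mL. Compound 3 `Cc1cn2cc(-c3cc4ccc(N5CCN(C)CC5)cc4oc3=O)nc2c(C)n1` differs from compound 2 in one place: 4-methylpiperazin-1-yl in place of 4-ethyl-3-methylpiperazin-1-yl on an aromatic carbon. Compound 1 also carries 4-methylpiperazin-1-yl, and its result is the limit < 10 ng.h/mL. A clear drop in this assay is therefore expected, though two compounds give thin support. The expected change is a 3.7-fold lower number from compound 2 to compound 3 (0.56 log units; beyond the scatter). For compound 3 the estimate is 300 ng.h/mL, with the result expected between 50 ng.h/mL and 1200 ng.h/mL.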

Compound 3, area under the concentration-time curve: 530 ng.h/mL
Compound 3: the middle estimate sits 1.8-fold (0.25 log units) below what was measured; low and high end bracket the measured number.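

In this assay, replacing 4-ethyl-3-methylpiperazin-1-yl with 4-methylpiperazin-1-yl gives a 2.1-fold lower number from compound 2 to compound 3 (0.32 log units; beyond the scatter), a modest step, so this smaller piperazine does not by itself bring a result down to that of compound 1. Compound 1 has a limit and not a number: the limit of < 10 ng.h/mL in this assay, at which 1 of the 3 values shown sits. With the piperazine unchanged, methyl in place of hydrogen on an aromatic carbon gives an at least 53-fold higher number from compound 1 to compound 3 (1.72 log units; beyond the scatter), a large step. The compounds shown leave open how much of the piperazine step belongs to the ethyl group and how much to the ring methyl. They also leave open how a morpholine would fare at this position.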